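The compounds below may be only part of what the source reports. "The series", "measured", "known", "first", "only" and "open" are said of these compounds alone.

Measured compounds in a functional assay on PC-3 cells (Homo sapiens) for antiproliferative activity, read by sulforhodamine B assay, with a stated time of 48 h, tested at 50 uM; a higher number here means more inhibition at the concentration tested (going by the name of the read-out), a lower number less inhibition:
compound 1 `CC1=CC[C@H](C(C)C)c2cc(C)c(OC(=O)c3ccc(C)cc3)cc21`, 49.6%
compound 2 `CC1=CC[C@H](C(C)C)c2cc(C)c(OC(=O)c3ccc([N+](=O)[O-])cc3)cc21`, 36.7%
compound 3 `CC1=CC[C@H](C(C)C)c2cc(C)c(OC(=O)c3cccc(C)c3)cc21`, 38.6%

Compound 4 `CC1=CC[C@H](C(C)C)c2cc(C)c(OC(=O)c3cccc([N+](=O)[O-])c3)cc21` is not yet measured. The cores of compound 1 and compound 3 differ by 3-methylphenyl in place of 4-methylphenyl on a carbonyl carbon, a step of a number 11 percentage points lower from compound 1 to compound 3 (beyond the scatter). Compound 2 and compound 3 differ by a number 1.9 percentage points higher from compound 2 to compound 3 (within the scatter).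

The change from compound 3 to compound 4 is nitro in place of methyl on an aromatic carbon. The same kind of change has been measured once, from compound 1 to compound 2, as nitro in place of methyl on an aromatic carbon, giving a number 12.9 percentage points lower from compound 1 to compound 2 (beyond the scatter). The place is not identical: in compound 1 the methyl sits para to a large group, in compound 3 meta to a large group, so the change is of the same kind, not the same.

Within the data shown here, for compound 4 a step of about a number 10.6 percentage points lower from compound 3 to compound 4 (beyond the scatter) in this assay is expected, resting on the single earlier step of a number 12.9 percentage points lower from compound 1 to compound 2 (beyond the scatter) and on the starting value of compound 3, 38.6%. With one precedent only, the range is kept wide. Compound 4 is estimated at 28%, with an expected span from 17% to 40%.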

Compound 4, a percentage reported as inhibition, at one concentration (the size of the read-out at that concentration, not a potency): 36.9%
Compound 4: the middle estimate sits 8.9 percentage points below what was measured, and the stated range covers the measured number.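

In this assay, the step for nitro in place of methyl on an aromatic carbon is a number 1.7 percentage points lower from compound 3 to compound 4 (within the scatter), and the two examples of this change cannot be told apart: the same change on two cores in this assay, a number 12.9 percentage points lower (beyond the scatter) from compound 1 to compound 2 and a number 1.7 percentage points lower (within the scatter) from compound 3 to compound 4, 11.2 percentage points apart, within the scatter of two such steps. Among these compounds, the change can therefore be carried from one core to the other without a measured conflict, but this does not establish a shared step size, as only two pairs exist and only the step on the core of compound 1 lies beyond the scatter. Among the compounds shown here, with nitro in both compounds, 3-nitrophenyl in place of 4-nitrophenyl gives a number 0.2 percentage points higher from compound 2 to compound 4 (within the scatter), while 3-nitrophenyl in place of 4-methylphenyl gives a number 12.7 percentage points lower from compound 1 to compound 4 (beyond the scatter), leaving compound 1 as the only compound that stands apart from the others in this assay.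

The compounds shown carry only methyl or nitro on the phenyl ring of the ester, so it remains open how an amine, a carboxylic acid or a longer alkyl chain there would read. Potency also remains open, as each number comes from a single tested concentration.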